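This account rests on a few compounds, and the source may have more. Where it says the series, first, only, none or still open, it means among the compounds named here.

The measured compounds in a physicochemical assay for solubility, with a stated time of 3 days, at pH 7; a lower number here means a less soluble compound, a higher number a more soluble compound:

compound 1 `CN1CCC(Oc2ccc(-c3nc4cc(C(N)=O)ccc4[nH]3)cc2)C1` — "not determined" (no result reported)
compound 2 `NC(=O)c1ccc2[nH]c(-c3ccc(OC4CCCNC4)cc3)nc2c1` — > 400000 nM
compound 3 `NC(=O)c1ccc2[nH]c(-c3ccc(OCC4CCCNC4)cc3)nc2c1` — "not determined" (no result reported)

Compound 1 stands without a number in this assay; no result was reported for it. Of the three entries, only compound 2 carries a reading, and that reading is a limit of the assay rather than a number: compound 2 gives > 400000 nM in this assay. Compound 3 likewise has no reported result. Among the compounds with values here, the one reading that exists sits at the limit, (the limit of > 400000 nM in this assay, at which 1 of the 3 values shown sits).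

The account now turns to compound 4 `NC(=O)c1ccc2[nH]c(-c3ccc(OCC4CCNCC4)cc3)nc2c1`, which is not yet measured. It differs from compound 1 in one place: (piperidin-4-yl)methyl in place of 1-methylpyrrolidin-3-yl on an oxygen on an aromatic ring. No step between two measured compounds is shown here. Compound 1 itself has no number, so the size and direction of the step from compound 1 to compound 4 in this assay cannot be placed against a reading; what can be said is that the shared core is kept and only the group on the oxygen on the aromatic ring changes.

For compound 4 the solubility is expected to be 400000 nM, with a range from 100000 nM to 800000 nM, and it is estimated that the assay will most likely again report only a limit.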

Compound 4, solubility: > 400000 nM
Compound 4: a limit, no number (the forecaster's own chance of this, stated with the estimate: 70%); the middle value lies on the limit itself.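

Compound 2 and compound 4 each carry only a limit and not a number, so no step can be read between them: the limit of > 400000 nM in this assay, at which 2 of the 4 values shown sit.

The compounds shown leave open whether (piperidin-4-yl)methyl in place of piperidin-3-yl changes the read-out at all.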